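Methoxy on a terminal phenyl: notes on the series

The source may report more compounds than this note shows. Statements on the series, on what has been measured and on what is new or still open speak of the compounds shown alone.

Measured compounds:
Compound 1 `COc1ccc(-n2c(SCc3ccccc3)nnc2-c2cc(OC)c(OC)c(OC)c2)cc1`. In a functional assay on HT-29 cells (Homo sapiens) for inhibition, read by MTT assay, with a stated time of 48 h (a higher number here means a weaker inhibitor, a lower number a stronger inhibitor), compound 1 gives only a limit of the assay, > 60000 nM.
Compound 2 `COc1ccc(CSc2nnc(-c3cc(OC)c(OC)c(OC)c3)n2-c2ccc(OC)cc2)cc1`. In this assay compound 2 likewise gives only a limit, > 60000 nM.
Compound 3 `COc1cc(-c2nnc(SCC(=O)c3ccccc3)n2-c2ccc(N(C)C)cc2)cc(OC)c1OC`. In this assay compound 3 gives 45200 nM.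

Compound 1 and compound 2 differ in a single place: methoxy in place of hydrogen on an aromatic carbon. The step that the two limits leave unreadable from compound 1 to compound 2 cannot be sized because of the limit of > 60000 nM in this assay, at which 2 of the 3 values shown sit. Among the compounds with values here, compound 3 stands apart in that its value is the only number in the set; the two others are limits. The difference between the core of compound 3 and the core of compound 1 is not broken down here.

Compound 4 `COc1ccc(C(=O)CSc2nnc(-c3cc(OC)c(OC)c(OC)c3)n2-c2ccc(N(C)C)cc2)cc1` has not been measured in this assay. It differs from compound 3 by methoxy in place of hydrogen on an aromatic carbon. This is the same change as the one from compound 1 to compound 2, with the place described in the same words, and it occurs two times among the compounds shown. Within the data shown here, the one measured instance of it gives no readable size, so the expectation for compound 4 rests on compound 3 alone, on its value 45200 nM and on the unsized step from compound 1 to compound 2.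

The step that the estimate means is expected to be small, a 1.0-fold lower number from compound 3 to compound 4 (0.00 log units; within the scatter), within the scatter of the assay. Compound 4 is expected to give about 45000 nM in this assay, with an expected range from 20000 nM to 100000 nM. Given how close compound 3 sits to the limit, a fair chance remains that compound 4 is reported only as a limit.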

Compound 4, half-maximal inhibitory concentration: 64000 nM
Beside the measured number, compound 4's estimate is 1.4-fold (0.15 log units) below it; the range from low to high includes it.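

In this assay methoxy in place of hydrogen on an aromatic carbon, here phenyl to 4-methoxyphenyl within the benzoylmethyl group on the core of compound 3, gives a step that stays within the scatter (a 1.4-fold higher number from compound 3 to compound 4 (0.15 log units; within the scatter)). The other instance of the same change, on the core of compound 1, cannot be read, so no second size can be set beside this one: (the limit of > 60000 nM in this assay, at which 2 of the 4 values shown sit). The series therefore holds a single sized instance on a single core, which shows that the change makes no step beyond the scatter there, but shows neither that it carries unaltered to the core of compound 1 nor that it behaves differently on that core.

The compounds shown leave open whether a group other than methoxy on the same aromatic carbon, such as a primary amine or a carboxylic acid, would give a step beyond the scatter in this assay on either core. They also leave open what a longer chain in place of the benzoylmethyl group would do on the core of compound 3.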